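Methyl added on the ester-bearing chain carbon

The source may report more compounds than this note shows. Statements on the series, on what has been measured and on what is new or still open speak of the compounds shown alone.

Compound 2 `CCOC(=O)C(C)Oc1ccc(NC(=O)COc2ccc3ccccc3c2)cc1` carries a 1-(ethoxycarbonyl)ethyl group on the oxygen on the aromatic ring; in a functional assay for inhibition, read by spectrophotometry, tested at 200 ug/mL (on this read-out higher numbers stand for more inhibition at the one concentration tested (going by the name of the read-out) and lower numbers for less inhibition), compound 2 gives 25%. Compound 1 `CCOC(=O)CCCOc1ccc(NC(=O)COc2ccc3ccccc3c2)cc1` carries 3-(ethoxycarbonyl)propyl on that oxygen, and in this assay compound 1 gives 25%. Going by the values given here, the step of no change at the digits printed from compound 1 to compound 2 (within the scatter) shows that changing the side chain between these two esters left the read-out where it was, so compound 2 stands level with compound 1 and the series so far is flat.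

Compound 3 `CCOC(=O)C(C)(C)Oc1ccc(NC(=O)COc2ccc3ccccc3c2)cc1` is not yet measured. It differs from compound 2 by methyl in place of hydrogen on a saturated chain carbon bound to a carbonyl carbon, an oxygen on an aromatic ring and a saturated chain carbon. Among the compounds with values here, the only measured step that bears on it, from compound 1 to compound 2, lay within the scatter, and nothing in the data points to a different outcome for a further methyl on that chain carbon, so no step beyond the scatter is expected in this assay. The expected step is no change at the digits printed from compound 2 to compound 3 (within the scatter). Compound 3 is therefore estimated at 25%, within 10% to 40%.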

Compound 3, a percentage reported as inhibition, at one concentration (the size of the read-out at that concentration, not a potency): 22%
The estimate for compound 3 lay 3 percentage points above the measured number; the measured number falls inside the stated range.
By their numbers in this assay, from the lowest: compounds 3, 1 and 2 (each within the scatter of the next).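

In this assay the added methyl gives a number 3 percentage points lower from compound 2 to compound 3 (within the scatter) and so shows that this chain carbon, already carrying one methyl, takes a second one with no step beyond the scatter. The branched 1-(ethoxycarbonyl)-1-methylethyl group also gives a number 3 percentage points lower from compound 1 to compound 3 (within the scatter) when set against the unbranched ester, so the three esters cannot be told apart on this read-out. No measurement here bears on why the read-out stays level across these side chains.

As far as these compounds go, whether a carboxylic acid in place of the ethyl ester, or an amine on this chain carbon, would move the read-out beyond the scatter remains open. From the compounds shown here alone, with a single tested concentration, it also remains open whether these esters would separate at other concentrations.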